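This account rests on a few compounds, and the source may have more. Where it says the series, first, only, none or still open, it means among the compounds named here.

Compound 1 `Cc1ccc(CS/C(=C/c2ccc(F)c(C)c2)C(=O)c2ccc(Cl)cc2)cc1` is tested in a functional assay on DU-145 cells (Homo sapiens) for inhibition, read by trypan blue exclusion, with a stated time of 96 h (on this read-out higher numbers stand for weaker inhibition of growth and lower numbers for stronger inhibition of growth), and gives 25000 nM. Compound 2 `O=C(/C(=C\c1ccc(OC(F)(F)F)cc1)S(=O)(=O)c1ccc(Br)cc1)c1ccc(Br)cc1` gives 25000 nM in this assay; the two values are level at the digits shown and lie within the scatter, so no order between them can be drawn. Compound 3 `Cc1ccc(CS/C(=C/c2c[nH]c3ccc(Cl)cc23)C(=O)c2ccc(Cl)cc2)cc1` is not yet measured and differs from compound 1 in one place: 5-chloro-1H-indol-3-yl in place of 4-fluoro-3-methylphenyl on a double-bonded chain carbon bound to a double-bonded chain carbon. Among the measured compounds shown here, no measured pair spans this change, and both measured compounds sit at the same weak level, so the data give no direction. For the measured compounds named here, the expectation is a modest step toward stronger inhibition, a 2.5-fold lower number from compound 1 to compound 3 (0.40 log units; beyond the scatter), resting on no measured step. Compound 3 is estimated at 10000 nM, with a range from 2000 nM to 25000 nM.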

Compound 3, concentration for 50% growth inhibition: 1000 nM
Compound 3: middle estimate off by 10-fold (1.00 log units), on the high side; measured number outside the range, below it.
By their numbers in this assay, from the lowest: compound 3; then compounds 1 and 2 (each within the scatter of the next).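

At this place, on a double-bonded chain carbon bound to a double-bonded chain carbon, the group strongly affects this assay: 5-chloro-1H-indol-3-yl in place of 4-fluoro-3-methylphenyl gives a 25-fold lower number from compound 1 to compound 3 (1.40 log units; beyond the scatter) in the series' first clear separation. The level earlier pair could not show that a single change here moves the read-out. No available measurement accounts for the size of this step.

From the compounds shown here alone, the change brings in the chlorine, ring nitrogen and second ring together, so their separate contributions stay open. Whether a methoxy group or an amine could replace the chlorine also remains unanswered.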